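Removing the aromatic methyl from compound 1: working notes

A few compounds are considered here, and "the series" means these few. Any claim that something is new, unique, unknown or untested is made for them only; others in the source may bear on it.

In a functional assay on MDA-MB-231 cells (Homo sapiens) for antiproliferative activity, read by sulforhodamine B assay, with a stated time of 48 h (a higher number here means a weaker inhibitor, a lower number a stronger inhibitor), compound 1 `COc1ccc(C(=O)/C=C\Nc2ccc(-c3nc4cc(OC)c(OC)c(OC)c4s3)cc2C)cc1O` gives 12400 nM and compound 3 `COc1ccc(C(=O)/C=C\Nc2ccc(-c3nc4cc(OC)c(OC)c(OC)c4s3)cc2C)cc1[N+](=O)[O-]` gives 12400 nM, level at the digits shown and together the highest of the three numbers. Compound 2 `COc1ccc(C(=O)/C=C\Nc2ccc(-c3nc4cc(OC)c(OC)c(OC)c4s3)cc2C)cc1F` gives 2900 nM, the lowest of the three.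

Compound 4 `COc1ccc(C(=O)/C=C\Nc2ccc(-c3nc4cc(OC)c(OC)c(OC)c4s3)cc2)cc1O` keeps the hydroxy group of compound 1 and differs from it in one place: hydrogen in place of methyl on an aromatic carbon. This is hydrogen in place of methyl on an aromatic carbon, ortho to a large group and meta to a large group.

For the measured compounds named here, no measured step removes or alters that methyl. The three steps all exchange a group elsewhere on the molecule, so they serve only as a gauge of how far this series moves in this assay. They show a 4.3-fold lower number from compound 1 to compound 2 (0.63 log units; beyond the scatter) for fluoro in place of hydroxy, no change at the digits printed from compound 1 to compound 3 (within the scatter) for nitro in place of hydroxy, and a 4.3-fold higher number from compound 2 to compound 3 (0.63 log units; beyond the scatter) for nitro in place of fluoro.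

The data give no direction for the loss of the methyl, so no step beyond the scatter is expected. The expected step is a 1.2-fold lower number from compound 1 to compound 4 (0.09 log units; within the scatter). The estimate for compound 4 is 10000 nM, with an expected range of 3000 nM to 30000 nM.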

Compound 4, half-maximal inhibitory concentration: 18100 nM
Compound 4: middle estimate off by 1.8-fold (0.26 log units), on the low side, within the range that was stated.
By their numbers in this assay, from the lowest: compound 2; then compounds 1, 3 and 4 (each within the scatter of the next).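

In this assay, the exchange of methyl for hydrogen on this aromatic carbon, ortho to a large group and meta to a large group, gives a 1.5-fold higher number from compound 1 to compound 4 (0.16 log units; within the scatter), so with the hydroxy group of compound 1 in place the methyl can be lost without a shift beyond the scatter. For the compounds shown here, this is the first reading at this position, since the earlier steps all lay elsewhere on the molecule, and one of them, a 4.3-fold lower number from compound 1 to compound 2 (0.63 log units; beyond the scatter), goes beyond the scatter, as the loss of the methyl does not. No supporting data bear on why the number holds at this position.

Going by these compounds alone, whether the methyl can also be lost without a shift beyond the scatter when the fluoro group of compound 2 or the nitro group of compound 3 is present stays open, and compound 2 is the one to watch, as it holds the lowest number of the series so far. Also open, from the compounds shown here alone, is whether a different group on this aromatic carbon, such as an ethyl chain, a methoxy group or an amine, would move the number beyond the scatter.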